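The source may report more compounds than this note shows. Statements on the series, on what has been measured and on what is new or still open speak of the compounds shown alone.

These are working notes on the series. In a functional assay on KB cells (Homo sapiens) for cytotoxicity (a lower number here means that less compound is needed, a higher number that more compound is needed for the effect), compound 1 `Oc1ccc2nc(-c3ccccc3)cc(O)c2c1` gives 0.41 ug/mL. Compound 2 `Oc1cc(-c2ccccc2)nc2c(O)cccc12` reads > 10 ug/mL, and this is a limit of the assay and not a number. The unmeasured compound 3 `Oc1cc(-c2ccccc2)nc2c(F)cccc12` carries fluoro in place of hydroxy on an aromatic carbon, ortho to a fused ring: fluoro in place of hydroxy on an aromatic carbon. Going by the values given here, no measured step between compounds that differ in one place is available, so the expectation rests on two values only. A moderate move towards lower values in this assay is expected, because compound 1 gives 0.41 ug/mL and the shared core can thus give a measurable reading. The expected change is an at least 1.6-fold lower number from compound 2 to compound 3 (0.22 log units; that floor lies within the scatter), though a reading at the limit again remains quite possible. For compound 3 the estimated value is 6 ug/mL, with an expected range of 1 ug/mL to 30 ug/mL.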

Compound 3, half-maximal effective concentration: 0.53 ug/mL
Estimate against measurement, compound 3: 11-fold (1.05 log units) above, and the stated range ends above it.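

In this assay, fluoro in place of hydroxy on an aromatic carbon, ortho to a fused ring, gives an at least 18-fold lower number from compound 2 to compound 3 (1.27 log units; beyond the scatter). The change of this one group therefore separates a reading at the limit from a measurable reading, which shows that a substituent at this position can keep the compound in the measurable range and that hydroxy and fluoro differ sharply here. The size of the step is only a floor, as compound 2 stands at a limit and not at a number: the limit of > 10 ug/mL in this assay, at which 1 of the 3 values shown sits.

From the compounds shown here alone, it remains open whether the difference follows from the presence of fluoro or simply from the loss of hydroxy. Plain hydrogen, chloro, methoxy or an amine on the same carbon would help to separate these two readings.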